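Carbamate chain length in trimethoxyphenyl pyrazolines

A few compounds are considered here, and "the series" means these few. Any claim that something is new, unique, unknown or untested is made for them only; others in the source may bear on it.

Compound 1 `COC(=O)N1N=C(c2ccccc2)CC1c1cc(OC)c(OC)c(OC)c1` carries a methyl carbamate; in a functional assay on A549 cells (Homo sapiens) for antiproliferative activity, read by MTT assay, with a stated time of 48 h (a lower number here means a stronger inhibitor of growth, a higher number a weaker inhibitor of growth), compound 1 gives 2880 nM. Compound 2 `CCOC(=O)N1N=C(c2ccccc2)CC1c1cc(OC)c(OC)c(OC)c1` differs by methyl in place of hydrogen on a saturated chain carbon bound to an oxygen next to a carbonyl group, and in this assay compound 2 gives 6680 nM. That single change reads as a 2.3-fold higher number from compound 1 to compound 2 (0.37 log units; beyond the scatter). Compound 3 `CCOC(=O)N1N=C(c2cccc(OC)c2)CC1c1cc(OC)c(OC)c(OC)c1` adds a methoxy to the phenyl of compound 2; in this assay compound 3 gives 5920 nM. The step of a 1.1-fold lower number from compound 2 to compound 3 (0.05 log units; within the scatter) is within the scatter. The difference between the cores of compound 1 and compound 3 is not broken down here.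

Compound 4 `CCCOC(=O)N1N=C(c2cccc(OC)c2)CC1c1cc(OC)c(OC)c(OC)c1` is not yet measured. It differs from compound 3 by methyl in place of hydrogen on a saturated chain carbon, two bonds along the chain from an oxygen next to a carbonyl group. For the measured compounds named here, this is the same kind of change as the one from compound 1 to compound 2, not the same: there the methyl entered on a saturated chain carbon bound to an oxygen next to a carbonyl group, here it enters two bonds along the chain from that oxygen. Resting on compound 1 and compound 2, where the change gave a 2.3-fold higher number from compound 1 to compound 2 (0.37 log units; beyond the scatter), a step of similar size in the same direction is expected, a 1.7-fold higher number from compound 3 to compound 4 (0.23 log units; within the scatter). Compound 4 is therefore estimated at 10000 nM, within 4500 nM to 25000 nM.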

Compound 4, concentration for 50% growth inhibition: > 10000 nM
Compound 4 was reported as a limit; the forecaster's own chance of this, stated with the estimate: 15%; the middle value sits exactly at the limit.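

In this assay compound 4 gives > 10000 nM, which is a limit of the assay and not a number. The step reads as an at least 1.6-fold higher number from compound 3 to compound 4 (0.22 log units; that floor lies within the scatter); this is only a floor, so nothing shown argues against the change carrying over to the methoxy-bearing core, but its true size on that core remains unknown. Set beside the earlier step, the result does not establish whether the change has the same size on both cores: the same change on two cores in this assay, a 2.3-fold higher number (0.37 log units; beyond the scatter) from compound 1 to compound 2 and an at least 1.6-fold higher number (0.22 log units; that floor lies within the scatter) from compound 3 to compound 4; the limit leaves it open whether they differ

The compounds shown leave open whether a longer chain, such as butyl, a branched chain, such as isopropyl, or a chain ending in an amine would keep any growth inhibition in this assay. They also leave open how the methyl carbamate behaves with the methoxy on the phenyl, and so whether the methoxy has any effect on the first chain step.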